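This account rests on a few compounds, and the source may have more. Where it says the series, first, only, none or still open, it means among the compounds named here.

The compounds here share one core and were tested in a functional assay on A549 cells (Homo sapiens) for cytotoxicity, read by MTT assay, with a stated time of 4 days; on this read-out higher numbers stand for weaker inhibition and lower numbers for stronger inhibition. Compound 1 `Cc1c(O)ccc2c1[C@H](Cn1cc(-c3ccccc3)nn1)[C@@]13CC(=O)[C@@](C)(CC[C@@H]21)C3` carries a free hydroxyl on its aromatic ring. In this assay compound 1 reaches only a limit, > 20000 nM. Compound 2 `C=C1C(=O)[C@]23C[C@@]1(O)CC[C@H]2c1ccc(OS(=O)(=O)c2ccc(C)cc2)c(C)c1[C@@H]3Cn1cc(-c2ccccn2)nn1` differs from the others in several places at once, and in this assay compound 2 gives 2310 nM. Compound 3 `Cc1ccc(S(=O)(=O)Oc2ccc3c(c2C)[C@H](Cn2cc(-c4ccccc4)nn2)[C@@]24CC(=O)[C@@](C)(CC[C@@H]32)C4)cc1` carries a (4-methylphenyl)sulfonyl on an oxygen on an aromatic ring where compound 1 has hydrogen. In this assay compound 3 also gives only a limit, > 20000 nM. The step that the two limits leave unreadable from compound 1 to compound 3 cannot be read because both values sit at the limit of > 20000 nM in this assay, at which 2 of the 3 values shown sit. So compound 3 stands at the limit, together with compound 1, and only compound 2 shows a number.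

Compound 4 `Cc1ccc(S(=O)(=O)Oc2ccc3c(c2C)[C@H](Cn2cc(-c4ccc(Cl)cc4)nn2)[C@@]24CC(=O)[C@@](C)(CC[C@@H]32)C4)cc1` differs from compound 3 by chloro in place of hydrogen on an aromatic carbon, para to a large group on the phenyl of the triazole. For the measured compounds named here, no measured step touches this phenyl: the single one-place step, from compound 1 to compound 3, is unreadable, and compound 2 changes several places at once. There is therefore no ground to expect a shift beyond the scatter in this assay in either direction.

Compound 4 is accordingly expected to remain at the limit, an estimated 20000 nM with a range from 8000 nM to 50000 nM. The step of a number no higher from compound 3 to compound 4 (the limit leaves the size open) that this estimate implies is expected to be none beyond the scatter.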

Compound 4, half-maximal inhibitory concentration: > 20000 nM
Compound 4 gave a limit, no number; the forecaster's own chance of this, stated with the estimate: 70%; the middle value lies on the limit itself.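

In this assay compound 4 gives > 20000 nM as a limit, not a number. No step can be read from compound 3 to compound 4, because both sit at the same limit: the limit of > 20000 nM in this assay, at which 3 of the 4 values shown sit.

The compounds shown leave open whether chloro in place of hydrogen changes cytotoxicity at all, and which of compound 2's several differences goes with its measurable value.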